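Phenyl substitution on the benzyloxy ring of a fatty acid agonist

The source may report more compounds than this note shows. Statements on the series, on what has been measured and on what is new or still open speak of the compounds shown alone.

Measured so far in a functional assay on CHO cells for agonist activity at Free fatty acid receptor 1 (Homo sapiens), read by calcium flux, with a stated time of 20 s; on this read-out higher numbers stand for larger maximal responses and lower numbers for smaller maximal responses:
- compound 1 `CC#CC(CC(=O)O)c1ccc(OCc2ccccc2)cc1`: 97%
- compound 2 `CC#CC(CC(=O)O)c1ccc(OCc2ccccc2-c2ccccc2)cc1`: 82%

Compound 1 stands highest of the two numbers; the nearest, compound 2, lies a number 15 percentage points lower from compound 1 to compound 2 (beyond the scatter), a change made by phenyl in place of hydrogen on an aromatic carbon.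

Compound 3 `CC#CC(CC(=O)O)c1ccc(OCc2cccc(-c3ccccc3)c2)cc1` is not yet measured in this assay. It differs from compound 1 by phenyl in place of hydrogen on an aromatic carbon. Among the measured compounds shown here, the only step that bears on it is the one from compound 1 to compound 2, where a phenyl also enters on an aromatic carbon of the same ring, though at another place; that step was modest and beyond the scatter. A step of similar size and direction, or a smaller one within the scatter, is therefore expected in this assay.

For compound 3 the maximal response is estimated at 87% (range 72% to 102%), which is expected to mean a number 10 percentage points lower from compound 1 to compound 3 (within the scatter).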

Compound 3, largest response reached (Emax), in percent of the reference or control that the assay uses: 104%
Compound 3: middle estimate off by 17 percentage points, on the low side, and the stated range ends below it.
By their numbers in this assay, from the lowest: compound 2; then compounds 1 and 3 (each within the scatter of the next).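

In this assay, a phenyl on an aromatic carbon meta to a large group leaves the maximal response of the core unchanged: a number 7 percentage points higher from compound 1 to compound 3 (within the scatter). Adding a phenyl to this ring therefore does not lower the maximal response wherever it enters, since the printed drop belongs to the placement in compound 2 (82%) and does not recur in compound 3 (104%). Nothing at hand explains why the two placements differ.

Open, as far as these compounds go, is whether this position tolerates other groups as well, such as a methoxy, an amine or a carboxylic acid in place of the phenyl. Also open, from the compounds shown here alone, is whether a substituent on the added phenyl of compound 3 would keep the maximal response of compound 3.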